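Methoxy Out, Chloro In on the Benzylamine Arm

The compounds below may be only part of what the source reports. "The series", "measured", "known", "first", "only" and "open" are said of these compounds alone.

Three sulfonamides built on one shared core have been measured in a functional assay on Capan-2 cells (Homo sapiens) for inhibition, read by MTT assay, with a stated time of 72 h; on this read-out higher numbers stand for weaker inhibition of growth and lower numbers for stronger inhibition of growth. Compound 1 `O=S(=O)(NCCCNCc1ccccc1Cl)c1cc(C(F)(F)F)cc(C(F)(F)F)c1` gives 13000 nM, compound 2 `O=S(=O)(NCCCNCc1ccccc1)c1cc(C(F)(F)F)cc(C(F)(F)F)c1` gives 14000 nM, and compound 3 `COc1cccc(CNCCCNS(=O)(=O)c2cc(C(F)(F)F)cc(C(F)(F)F)c2)c1` gives 6400 nM. Compound 3 stands lowest of the three: its nearest neighbour is compound 1, as the step of a 2.0-fold lower number from compound 1 to compound 3 (0.31 log units; beyond the scatter) shows, and the step of a 2.2-fold lower number from compound 2 to compound 3 (0.34 log units; beyond the scatter) is of similar size. The step of a 1.1-fold higher number from compound 1 to compound 2 (0.03 log units; within the scatter) stays within the scatter.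

Compound 4 `O=S(=O)(NCCCNCc1ccc(Cl)cc1)c1cc(C(F)(F)F)cc(C(F)(F)F)c1` has not yet been measured. It differs from compound 3 by 4-chlorophenyl in place of 3-methoxyphenyl on a saturated chain carbon bound to an amine nitrogen. For the measured compounds named here, two measured steps bear on this change. The methoxy was seen entering as a 2.2-fold lower number from compound 2 to compound 3 (0.34 log units; beyond the scatter), so its loss is expected to raise the number by a modest amount. A chloro, present as 2-chlorophenyl in compound 1, made no difference beyond the scatter in a 1.1-fold higher number from compound 1 to compound 2 (0.03 log units; within the scatter). Compound 4 is therefore expected to show a step of a 1.9-fold higher number from compound 3 to compound 4 (0.27 log units; within the scatter). This would place compound 4 near the level of compound 2. The estimate for compound 4 in this assay is 12000 nM, with a range from 6000 nM to 25000 nM.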

Compound 4, concentration for 50% growth inhibition: 2700 nM
For compound 4 the middle estimate is 4.4-fold (0.65 log units) above the measured one, and the stated range ends above it.
By their numbers in this assay, from the lowest: compound 4; then compound 3; then compounds 1 and 2 (each within the scatter of the next).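

Chloro on this ring is not silent after all: in this assay it gives a 5.2-fold lower number from compound 2 to compound 4 (0.71 log units; beyond the scatter) as the 4-chlorophenyl group, although the 2-chlorophenyl group of compound 1 stayed within the scatter of compound 2. The two chloro isomers are themselves far apart, with a 4.8-fold lower number from compound 1 to compound 4 (0.68 log units; beyond the scatter) on this read-out, so the place of the chloro matters as much as its presence, and the step of a 2.4-fold lower number from compound 3 to compound 4 (0.37 log units; beyond the scatter) shows that the methoxy of compound 3 is not needed for a low number. Nothing available explains this dependence on place.

The compounds shown leave open whether a bromine or a methyl in place of the chloro of compound 4 would hold this level. They also leave open whether a longer chain in the shared core would keep it.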